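The source may hold more compounds than are shown below. What is called first, only, known or untested is meant among the compounds shown, and "the series" means these compounds.

Measured so far:
compound 1 `CN(C)CCCn1nc(C2=C(c3cn(C)c4ccccc34)C(=O)NC2=O)c2cccnc21` — in a functional assay on SMMC-7721 cells (Homo sapiens) for antiproliferative activity, read by MTT assay, with a stated time of 48 h (on this read-out lower numbers stand for stronger inhibition and higher numbers for weaker inhibition), compound 1 gives > 100000 nM, a limit of the assay.
compound 2 `CN1CCN(CCCn2nc(C3=C(c4cn(C)c5ccccc45)C(=O)NC3=O)c3cccnc32)CC1` — in this assay compound 2 gives > 100000 nM, also a limit of the assay.

Going by the values given here, compound 1 stands only at a limit in this assay, with no number of its own; the same holds for the one other value shown, (the limit of > 100000 nM in this assay, at which 2 of the 2 values shown sit). Among the compounds with values here, the single measured step, a step that the two limits leave unreadable from compound 1 to compound 2, is therefore of unreadable size and gives no direction.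

Compound 3 `CN(C)CCCn1nc(C2=C(c3cn(C)c4ccccc34)C(=O)N(c3ccccc3)C2=O)c2cccnc21` differs from compound 1 by phenyl in place of hydrogen on an amide-type nitrogen in a ring. Within the data shown here, no measured step touches this position, and the two limits give nothing to read from. The step to compound 3 is expected to stay unreadable, and compound 3 is expected to sit again at the limit, meaning a number no higher from compound 1 to compound 3 (the limit leaves the size open) of no readable size. The estimate for compound 3 is 100000 nM, with a range from 20000 nM to 300000 nM, most likely reported only as a limit.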

Compound 3, half-maximal inhibitory concentration: 31200 nM
The estimate for compound 3 lay 3.2-fold (0.51 log units) above the measured number, within the range that was stated.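

In this assay, going by these compounds alone, the amide-type nitrogen in the five-membered ring is the first position to give a readable change, with phenyl in place of hydrogen giving an at least 3.2-fold lower number from compound 1 to compound 3 (0.50 log units; beyond the scatter). Compound 1 stands at a limit, so this step has a bound and no exact size. Compound 3 is the only compound shown with a number of its own, and the other two stay at the limit: the limit of > 100000 nM in this assay, at which 2 of the 3 values shown sit.

Going by these compounds, the step from compound 1 to compound 2 cannot be read, so any difference between dimethylamino and 4-methylpiperazin-1-yl remains open, including when phenyl sits on the ring nitrogen. Also open, on these data alone, is whether the change is specific to phenyl or would also appear with methyl, benzyl or 4-chlorophenyl on that nitrogen.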